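The compounds below may be only part of what the source reports. "The series", "measured", "known", "first", "only" and "open" are said of these compounds alone.

Working notes on the series.

Of the compounds shown here, two have been measured so far in a functional assay on HCT-116 cells (Homo sapiens) for inhibition, read by MTT assay, with a stated time of 48 h; a higher number here means a weaker inhibitor, a lower number a stronger inhibitor. Compound 1 `Fc1cccc(F)c1CSc1nnc(-c2ccncc2)n1-c1ccccc1` gives 22100 nM in this assay. Compound 2 `COc1ccc(/C=N/NC(=O)CSc2nnc(-c3ccncc3)n2-c2ccccc2)cc1` gives 19200 nM in this assay. Compound 2 holds the lower of the two numbers, but the gap to compound 1 is within the usual scatter of repeated measurements, so the two stand together and neither can be called the stronger inhibitor on this evidence. Both numbers sit in the weak range.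

Compound 3 `O=C(CSc1nnc(-c2ccncc2)n1-c1ccccc1)N/N=C/c1ccccc1O` has not been measured in this assay. It differs from compound 2 in one place: 2-hydroxyphenyl in place of 4-methoxyphenyl on a carbon with a double bond to nitrogen. The shared core and the acylhydrazone linker are untouched. Within the data shown here, no step between measured compounds bears on a change of this kind, so there is no measured precedent for it.

The expectation for compound 3 is a step of a 1.1-fold lower number from compound 2 to compound 3 (0.03 log units; within the scatter) in this assay, that is, no change beyond the scatter in either direction. The estimate for compound 3 in this assay is 18000 nM, with a range from 7000 nM to 45000 nM.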

Compound 3, half-maximal inhibitory concentration: 7060 nM
Compound 3: the middle estimate sits 2.5-fold (0.41 log units) above what was measured, and the stated range covers the measured number.
By their numbers in this assay, from the lowest: compound 3; then compounds 2 and 1 (each within the scatter of the next).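

In this assay the group on a carbon with a double bond to nitrogen turns out not to be silent: 2-hydroxyphenyl in place of 4-methoxyphenyl gives a 2.7-fold lower number from compound 2 to compound 3 (0.43 log units; beyond the scatter) and is a modest step, yet one beyond the scatter. Among these compounds, this is the first step between measured compounds that differ in one place, so it is the first direct sign that a change at this position can shift the number while the shared core and the acylhydrazone linker stay untouched. The entering group has 1 hydrogen-bond donor where the leaving group has 0, but nothing measured here ties the step to that count or to any other feature of the change.

The step cannot yet be divided between the hydroxy and methoxy groups and their places on the ring, and the compounds shown leave open where 2-methoxyphenyl and 4-hydroxyphenyl would fall on this carbon. They also leave open whether 2-aminophenyl, with an amine in place of the hydroxy group, would keep the lower number seen with compound 3.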